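A few compounds are considered here, and "the series" means these few. Any claim that something is new, unique, unknown or untested is made for them only; others in the source may bear on it.

Measured in an assay on cells for inhibition of Polyunsaturated fatty acid 5-lipoxygenase (Homo sapiens), read by HPLC, with stated times of 15 min and 10 min; a lower number here means a stronger inhibitor, a higher number a weaker inhibitor:
Compound 1 `COc1cccc(-c2nc3ccc(C)cn3c2NC2CCCCC2)c1`: 1220 nM
Compound 2 `Oc1ccc(-c2nc3ccc(Br)cn3c2NC2CCCCC2)cc1`: 1100 nM
Compound 3 `Cc1ccc2nc(-c3cccc(Oc4ccccc4)c3)c(NC3CCCCC3)n2c1`: 500 nM

Among these three, compound 1 gives the highest number in this assay; compound 2 sits within the scatter of it, and only the step of a 2.4-fold lower number from compound 1 to compound 3 (0.39 log units; beyond the scatter) lies beyond the scatter. Compound 4 `COc1ccc(-c2nc3ccc(C)cn3c2NC2CCCCC2)cc1` differs from compound 1 by 4-methoxyphenyl in place of 3-methoxyphenyl on an aromatic carbon. Going by the values given here, no measured step moves the methoxy group around its ring; the single known step, a 2.4-fold lower number from compound 1 to compound 3 (0.39 log units; beyond the scatter), changes what sits on the oxygen instead, and so shows only that this part of the molecule tolerates alteration. For compound 4 the expected step is therefore small, a 1.1-fold lower number from compound 1 to compound 4 (0.04 log units; within the scatter), with no clear direction beyond the scatter. Compound 4 is estimated at 1100 nM, within a range from 450 nM to 2700 nM.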

Compound 4, half-maximal inhibitory concentration: 1300 nM
Estimate against measurement, compound 4: 1.2-fold (0.07 log units) below; measured number inside the range.
By their numbers in this assay, from the lowest: compound 3; then compounds 2, 1 and 4 (each within the scatter of the next).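

Moving the methoxy group, with 4-methoxyphenyl in place of 3-methoxyphenyl, gives a 1.1-fold higher number from compound 1 to compound 4 (0.03 log units; within the scatter) and so offers the first direct test of where this group sits on its ring. The earlier step changed what sits on the oxygen, whereas this one keeps the same atoms and only joins them differently, and the number stays within the scatter. No measurement at hand accounts for this result.

Still open, as far as these compounds go, is whether this insensitivity holds for other groups. An amine or a carboxylic acid in place of the methoxy group might respond differently to the same move.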